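A few compounds are considered here, and "the series" means these few. Any claim that something is new, unique, unknown or untested is made for them only; others in the source may bear on it.

Measured in an ADME assay on HepG2 cells (Homo sapiens) for cytotoxicity, with a stated time of 72 h; a higher number here means that more compound is needed for the effect, a lower number that less compound is needed:
Compound 1 `Cc1cc(NC(=O)Nc2ccc(C(C)(C)C)cc2)c2ccccc2n1`: 17000 nM
Compound 2 `Cc1cc(NC(=O)Nc2ccc(O)cc2)c2ccccc2n1`: > 25000 nM

Compound 2 has no exact number in this assay: its > 25000 nM is a limit of the assay. Its position is therefore known only through (the limit of > 25000 nM in this assay, at which 1 of the 2 values shown sits). Compound 3 `Cc1cc(NC(=O)Nc2ccc(SC(F)(F)F)cc2)c2ccccc2n1`, not yet measured, carries (trifluoromethyl)sulfanyl in place of hydroxy on an aromatic carbon, para to a large group ((trifluoromethyl)sulfanyl in place of hydroxy on an aromatic carbon).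

For the measured compounds named here, one measured step bears on this change, the replacement of tert-butyl by hydroxy: an at least 1.4-fold higher number from compound 1 to compound 2 (0.16 log units; that floor lies within the scatter). That step rests on a limit, and its floor lies within the scatter, so it gives only weak guidance on size. Going by the values given here, compound 3 loses the hydroxy, as a move in the reverse direction of that step would, and the only measured compound without it is compound 1, at 17000 nM. A modest step towards a lower number is therefore expected, leaving compound 3 near compound 1. The expected change is an at least 1.9-fold lower number from compound 2 to compound 3 (0.28 log units; that floor lies within the scatter). For compound 3 the estimated value is 13000 nM, with an expected range from 6000 nM to 25000 nM.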

Compound 3, half-maximal effective concentration: 20000 nM
Compound 3: the middle estimate sits 1.5-fold (0.19 log units) below what was measured; the measured number falls inside the stated range.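

In this assay, the position now has a second exact number, and exchanging tert-butyl for (trifluoromethyl)sulfanyl gives a 1.2-fold higher number from compound 1 to compound 3 (0.07 log units; within the scatter) and so does not separate these two groups, which differ in size and make-up but share this aromatic carbon. The step that removes the hydroxy, with its hydrogen-bond donor, gives an at least 1.2-fold lower number from compound 2 to compound 3 (0.09 log units; that floor lies within the scatter) and thus offers only a floor, one that does not show that the hydroxy compound differs from the other two. Compound 2 has no exact number, and its position is known only through a single limit: the limit of > 25000 nM in this assay, at which 1 of the 3 values shown sits.

The three compounds therefore show no measured effect of this substituent in this assay, but they cover only a neutral hydroxy and two larger neutral groups, so they cannot say whether an amine or a carboxylic acid on this carbon would give a clear difference. On these data alone, it also remains open how far the hydroxy compound actually stands from the other two, and whether the same flat picture would hold with a longer alkyl chain at this place.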